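This account rests on a few compounds, and the source may have more. Where it says the series, first, only, none or still open, it means among the compounds named here.

Measured so far in a functional assay on RCC4 cells (Homo sapiens) for inhibition, read by XTT assay, with a stated time of 4 days; on this read-out higher numbers stand for weaker inhibition and lower numbers for stronger inhibition:
compound 1 `Cc1cccc(Nc2nc(-c3ccncc3)c(CN(C)C)s2)c1`: 16200 nM
compound 2 `Cc1cc(C)cc(Nc2nc(-c3ccncc3)cs2)c1`: 4570 nM

In this assay compound 1 gives 16200 nM, the highest of the two numbers at hand. Compound 2 gives 4570 nM, and the gap between the two lies beyond the usual scatter, so compound 2 is the stronger inhibitor of the pair. Among the measured compounds shown here, the two compounds differ at more than one place, and no single-site step between measured compounds is available, so the weight of any one change on the shared core cannot be read from these two values.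

Compound 3 `Cc1cccc(Nc2nc(-c3ccncc3)c(C(N)=O)s2)c1` is the next compound to be measured in this assay. It differs from compound 1 by carbamoyl in place of (dimethylamino)methyl on an aromatic carbon. Nothing in the measured set shows what such an exchange does on this core, so the expectation rests on compound 1 alone and on the absence of any shown trend. The expected step is a 1.2-fold lower number from compound 1 to compound 3 (0.06 log units; within the scatter), that is, none beyond the usual scatter in either direction. Compound 3 is therefore expected to give about 14000 nM, within a range from 5000 nM to 40000 nM.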

Compound 3, half-maximal inhibitory concentration: 19500 nM
For compound 3 the middle estimate is 1.4-fold (0.14 log units) below the measured one; the range from low to high includes it.
By their numbers in this assay, from the lowest: compound 2; then compounds 1 and 3 (each within the scatter of the next).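

In this assay, among the compounds shown here, carbamoyl in place of (dimethylamino)methyl on the aromatic carbon next to the ring sulfur gives a 1.2-fold higher number from compound 1 to compound 3 (0.08 log units; within the scatter) and is the only single-site step at hand. It shows what the earlier pair could not: at this position, these two groups cannot be told apart on this read-out, although they differ in heavy-atom count, in hydrogen-bond donors and in the double bond outside aromatic rings. Nothing at hand bears on a reason for this result.

The compounds shown leave open whether a carboxylic acid, a primary aminomethyl group or a longer chain in the same place would separate from these two values beyond the scatter on the core of compound 1. For the compounds shown here, also open is how either group compares with a plain hydrogen at this carbon, since no single-site step links compound 2 to compound 1 or compound 3.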